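A few compounds are considered here, and "the series" means these few. Any claim that something is new, unique, unknown or untested is made for them only; others in the source may bear on it.

Compound 1 `O=C(NCc1ccc(C(F)(F)F)nc1N1CCCC1)Nc1cccc2[nH]c(=O)ccc12`: 0.94 nM
Compound 2 `CCCCOc1nc(C(F)(F)F)ccc1CNC(=O)Nc1cccc2[nH]c(=O)ccc12`: 4 nM

In an assay on HEK cells for antagonist activity at transient receptor potential cation channel subfamily V member 1 (Homo sapiens), read by FLIPR (on this read-out higher numbers stand for weaker inhibition and lower numbers for stronger inhibition), compound 2 gives 4 nM, the higher of the two numbers; the nearest is compound 1, which gives 0.94 nM. Compound 3 `O=C(NCc1ccc(C(F)(F)F)nc1-c1ccc(F)cc1)Nc1cccc2[nH]c(=O)ccc12` differs from compound 2 by 4-fluorophenyl in place of butoxy on an aromatic carbon. Among the compounds with values here, only one measured step concerns this position: a 4.3-fold higher number from compound 1 to compound 2 (0.63 log units; beyond the scatter). It shows that the group on this aromatic carbon can move the number beyond the scatter, but neither pyrrolidin-1-yl nor butoxy resembles 4-fluorophenyl, so its direction is a weak guide. The expected change is a 1.3-fold lower number from compound 2 to compound 3 (0.12 log units; within the scatter), small and uncertain in direction. Compound 3 is therefore estimated at 3 nM, ranging from 0.7 nM to 15 nM.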

Compound 3, half-maximal inhibitory concentration: 1.93 nM
Estimate against measurement, compound 3: 1.6-fold (0.19 log units) above, and the stated range covers the measured number.
By their numbers in this assay, from the lowest: compound 1; then compound 3; then compound 2.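

In this assay, 4-fluorophenyl on this aromatic carbon gives a 2.1-fold lower number from compound 2 to compound 3 (0.32 log units; beyond the scatter) and a 2.1-fold higher number from compound 1 to compound 3 (0.31 log units; beyond the scatter), placing it between butoxy and pyrrolidin-1-yl. The position therefore accepts a six-membered aromatic ring of carbon only, a type of group that neither earlier compound carried here. Nothing available explains this order. The compounds shown leave open what the fluorine itself contributes, and how a plain phenyl, a morpholine or a primary amine on this carbon would compare.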